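Sulfanyl for sulfonyl: solubility notes on the series

The compounds below may be only part of what the source reports. "The series", "measured", "known", "first", "only" and "open" are said of these compounds alone.

compound 1 `COC(=O)c1ccc(C(=O)/C(=C\c2ccc(F)c([N+](=O)[O-])c2)SCc2ccc(Br)cc2)cc1`: < 1000 ug/mL
compound 2 `O=C(O)c1ccc(C(=O)/C(=C\c2ccc(F)c([N+](=O)[O-])c2)S(=O)(=O)Cc2ccc(Br)cc2)cc1`: < 1000 ug/mL
compound 3 `O=C(O)c1ccc(C(=O)/C(=C\c2ccc(F)cc2[N+](=O)[O-])SCc2ccc(Br)cc2)cc1`: < 1000 ug/mL

Across the series a physicochemical assay for solubility (on this read-out lower numbers stand for lower solubility and higher numbers for higher solubility), shows the limit of < 1000 ug/mL in this assay, at which 3 of the 3 values shown sit, and no number. Compound 2 stands at < 1000 ug/mL in this assay and that value is a limit. Compound 4 `O=C(O)c1ccc(C(=O)/C(=C\c2ccc(F)c([N+](=O)[O-])c2)SCc2ccc(Cl)cc2)cc1` has not yet been measured. Its change from compound 2 is (4-chlorobenzyl)sulfanyl in place of (4-bromobenzyl)sulfonyl on a double-bonded chain carbon bound to a carbonyl carbon and a double-bonded chain carbon. Going by the values given here, no measured step is available for comparison. The expected step in this assay has no set direction and stays within the usual scatter (a step that the limit leaves unreadable from compound 2 to compound 4). Compound 4 is estimated at 600 ug/mL with an expected range from 150 ug/mL to 1000 ug/mL.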

Compound 4, solubility: < 1000 ug/mL
Compound 4 ended at the assay's limit; the forecaster's own chance of this, stated with the estimate: 85%; the middle value is on the limit's open side.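

No step can be read from compound 2 to compound 4 in this assay, as both values are limits. The compounds shown leave open where any of them truly lies: the limit of < 1000 ug/mL in this assay, at which 4 of the 4 values shown sit.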